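The source may report more compounds than this note shows. Statements on the series, on what has been measured and on what is new or still open speak of the compounds shown alone.

Measured compounds:
- compound 1, `CC(=O)OC/C(=C\C1CCCCC1)C(=O)c1ccccc1`: in a functional assay on WiDr cells (Homo sapiens) for inhibition, read by sulforhodamine B assay, with a stated time of 48 h (on this read-out lower numbers stand for stronger inhibition of growth and higher numbers for weaker inhibition of growth), compound 1 gives 21000 nM
- compound 2, `O=C(OC/C(=C\C1CCCCC1)C(=O)c1ccccc1)c1ccccc1`: in this assay compound 2 gives 19000 nM
- compound 3, `CC(=O)OC/C(=C/c1ccc(Cl)cc1Cl)C(=O)c1ccccc1`: in this assay compound 3 gives 19000 nM

Compound 1 and compound 2 differ in one place, (phenyl in place of methyl on a carbonyl carbon), and this gave a 1.1-fold lower number from compound 1 to compound 2 (0.04 log units; within the scatter). Compound 3 shares the acetyl ester with compound 1, but how its core differs from the core of compound 1 is not broken down here; what the two values show is that compound 3 and compound 1 lie within the scatter of each other in this assay, as do compound 3 and compound 2.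

Compound 4, `O=C(OC/C(=C/c1ccc(Cl)cc1Cl)C(=O)c1ccccc1)c1ccccc1`, has not yet been measured. It differs from compound 3 by phenyl in place of methyl on a carbonyl carbon, the same change that separates compound 1 from compound 2, at a place described in the same words. Because the measured pair gave a 1.1-fold lower number from compound 1 to compound 2 (0.04 log units; within the scatter), a step of similar size is expected for compound 4, namely a 1.1-fold lower number from compound 3 to compound 4 (0.05 log units; within the scatter). On that basis compound 4 is estimated to give 17000 nM in this assay, with an expected range from 8000 nM to 36000 nM.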

Compound 4, concentration for 50% growth inhibition: 8700 nM
Estimate against measurement, compound 4: 2.0-fold (0.29 log units) above; low and high end bracket the measured number.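

In this assay, phenyl in place of methyl on a carbonyl carbon, the change from acetyl to benzoyl, gave a 2.2-fold lower number from compound 3 to compound 4 (0.34 log units; beyond the scatter), a modest step that lies beyond the scatter. Set beside the earlier step, it does not separate from it: the same change on two cores in this assay, a 1.1-fold lower number (0.04 log units; within the scatter) from compound 1 to compound 2 and a 2.2-fold lower number (0.34 log units; beyond the scatter) from compound 3 to compound 4, 2.0-fold (0.30 log units) apart, within the scatter of two such steps The two cores therefore give no ground for saying that the core alters the size of this step, but this does not prove that the step carries over unchanged, as only two cores are compared and just one of the two steps lies beyond the scatter.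

The compounds shown leave open what a longer chain on the carbonyl carbon, or an amine or a carboxylic acid carried on the benzoyl group, would do in place of the methyl or phenyl. They also leave open whether the step would stay within the same range on any core other than these two.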